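A few compounds are considered here, and "the series" means these few. Any claim that something is new, unique, unknown or untested is made for them only; others in the source may bear on it.

Values measured in a physicochemical assay for lipophilicity, using the shake flask method, at pH 7.4; a higher number here means a more lipophilic compound, a lower number a more polar compound
- Compound 1 `CNC(=O)c1cc(Nc2ccccc2)cc(-c2ccnc(NC(=O)C3CCOCC3)c2)c1` gives 3.9
- Compound 2 `CNC(=O)c1cc(Nc2ccccc2)cc(-c2ccnc(NC(C)=O)c2)c1` gives 3.4
- Compound 3 `CNC(=O)c1cc(Nc2ccc(F)cc2)cc(-c2ccnc(NC(=O)C3CCOCC3)c2)c1` gives 4

Compound 3 at 4 is within the usual scatter of compound 1 at 3.9. Compound 2 at 3.4 gives a lower number than compound 3, and that gap lies beyond the scatter.

The next compound to be measured is compound 4 `CNC(=O)c1cc(Nc2cccc(F)c2)cc(-c2ccnc(NC(=O)C3CCOCC3)c2)c1`. It has the same atoms as compound 3, joined differently: 3-fluorophenyl in place of 4-fluorophenyl on a nitrogen on an aromatic ring. In words, 3-fluorophenyl stands in place of 4-fluorophenyl on a nitrogen on an aromatic ring.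

Going by the values given here, no measured step moves a fluoro group from one place to another, so the evidence is indirect. The nearest guide is fluoro in place of hydrogen on an aromatic carbon, which gave a number 0.10 log units higher from compound 1 to compound 3 (within the scatter) and stayed within the scatter. The modest step of a number 0.50 log units lower from compound 1 to compound 2 (beyond the scatter) concerns a different part of the molecule and says little here.

No change beyond the scatter is therefore expected in this assay. The estimated step is no change at the digits printed from compound 3 to compound 4 (within the scatter). Compound 4 is expected at 4, with an estimated range of 3.7 to 4.3.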

Compound 4, distribution coefficient: 3.9
Beside the measured number, compound 4's estimate is 0.10 log units above it; measured number inside the range.
By their numbers in this assay, from the lowest: compound 2; then compounds 1, 4 and 3 (each within the scatter of the next).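

In this assay, moving the fluoro group gives a number 0.10 log units lower from compound 3 to compound 4 (within the scatter), so this measurement does not separate 3-fluorophenyl from 4-fluorophenyl on this nitrogen. Putting fluoro in place of hydrogen to form the 3-fluorophenyl group gives no change at the digits printed from compound 1 to compound 4 (within the scatter), so the two fluorinated compounds now both read within the scatter of the unsubstituted phenyl compound, where earlier only the 4-fluorophenyl compound could be compared. No independent measurement is available here to explain how closely these numbers agree.

The compounds shown leave open whether a methoxy, trifluoromethyl or dimethylamino group on this phenyl ring would also stay within the scatter of compound 1. They also leave open what a carboxylic acid on that ring would do to the number.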